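A few compounds are considered here, and "the series" means these few. Any claim that something is new, unique, unknown or untested is made for them only; others in the source may bear on it.

Series of three analogues sharing one core, differing only in the group on the five-membered aromatic ring with 3 nitrogen, all measured in an assay on isolated protein for inhibition of Indoleamine 2,3-dioxygenase 2 (Homo sapiens); a lower number here means a stronger inhibitor, a higher number a weaker inhibitor:

compound 1 `CCCCc1cn(CCNc2nonc2/C(=N/O)Nc2ccc(F)c(Br)c2)nn1`: 830 nM
compound 2 `CCC(O)c1cn(CCNc2nonc2/C(=N/O)Nc2ccc(F)c(Br)c2)nn1`: 947 nM
compound 3 `CC(C)CC(C)(O)c1cn(CCNc2nonc2/C(=N/O)Nc2ccc(F)c(Br)c2)nn1`: 689 nM

Compound 3 is taken as the point of departure. The three numbers lie close together: a 1.2-fold lower number from compound 1 to compound 3 (0.08 log units; within the scatter), a 1.4-fold lower number from compound 2 to compound 3 (0.14 log units; within the scatter) and a 1.1-fold higher number from compound 1 to compound 2 (0.06 log units; within the scatter) are each within the scatter, so no separation among compound 1, compound 2 and compound 3 can be claimed in this assay.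

The next compound, compound 4 `CC(C)(OCCO)c1cn(CCNc2nonc2/C(=N/O)Nc2ccc(F)c(Br)c2)nn1`, carries a change at the same position: 1-(2-hydroxyethoxy)-1-methylethyl in place of 1-hydroxy-1,3-dimethylbutyl on an aromatic carbon. The measured steps that touch this position are the three above, and each of them, whether a butyl, a 1-hydroxypropyl or a 1-hydroxy-1,3-dimethylbutyl sits there, left the number within the scatter. Within the data shown here, the new group keeps one hydrogen-bond donor and adds an oxygen in the chain; nothing among the measured compounds shows such an addition, so the expectation rests on the indifference of this position seen so far. A step of a 1.1-fold higher number from compound 3 to compound 4 (0.04 log units; within the scatter) is therefore expected, that is, none beyond the scatter.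

Compound 4 is expected to give 750 nM in this assay, with a likely range from 350 nM to 1600 nM.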

Compound 4, half-maximal inhibitory concentration: 1170 nM
Compound 4: middle estimate off by 1.6-fold (0.19 log units), on the low side; the measured number falls inside the stated range.
By their numbers in this assay, from the lowest: compounds 3, 1, 2 and 4 (each within the scatter of the next).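

In this assay the ether-bearing 1-(2-hydroxyethoxy)-1-methylethyl group stays within the scatter of all three earlier groups, with a 1.7-fold higher number from compound 3 to compound 4 (0.23 log units; within the scatter) and a 1.2-fold higher number from compound 2 to compound 4 (0.09 log units; within the scatter) and also a 1.4-fold higher number from compound 1 to compound 4 (0.15 log units; within the scatter) each printed as such. The earlier compounds shown here varied the chain only as butyl, 1-hydroxypropyl and 1-hydroxy-1,3-dimethylbutyl, whereas this change swaps a carbon for an oxygen within the group, keeping the same heavy-atom total and hydrogen-bond donor count while adding a hydrogen-bond acceptor, and that added acceptor produces no separation from any of the other three compounds. The position on the aromatic carbon therefore remains without a measurable preference among these four groups, and no explanation can be offered for the numbers, as nothing measured here bears on the reason for this indifference.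

Open is whether any group at this position can move the number beyond the scatter in either direction, since a primary amine, a carboxylic acid, a phenyl ring or a much longer chain such as octyl lies outside the four compounds shown. Also open, going by these compounds, is whether this indifference would hold with a different substitution on the rest of the shared core, as all four compounds carry the same remainder.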